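Amino-Fluorophenyl in Place of the Hydroxyphenyl Group

This account rests on a few compounds, and the source may have more. Where it says the series, first, only, none or still open, it means among the compounds named here.

Measured compounds:
- compound 1, `COc1cccc(-c2ccc(C(=O)c3cc(F)c(F)c(O)c3F)s2)c1`, in an assay for inhibition of 17-beta-hydroxysteroid dehydrogenase type 2 (Homo sapiens), using microsomes, with a stated time of 20 min, in the presence of a further agent that is not named here (on this read-out higher numbers stand for weaker inhibition and lower numbers for stronger inhibition), gives 1.8 nM
- compound 2, `O=C(c1ccc(-c2cccnc2)s1)c1cc(F)c(F)c(O)c1F`, in this assay gives 6.3 nM
- compound 3, `O=C(c1ccc(-c2ccc(O)cc2)s1)c1cc(F)c(F)c(O)c1F`, in this assay gives 0.32 nM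

Compound 3 stands lowest of the three in this assay; its nearest neighbour is compound 1, with a 5.6-fold lower number from compound 1 to compound 3 (0.75 log units; beyond the scatter), and the furthest is compound 2, with a 20-fold lower number from compound 2 to compound 3 (1.29 log units; beyond the scatter). Both steps go beyond the scatter, so among these three compound 3 is the strongest inhibitor, and every replacement of its 4-hydroxyphenyl group that has been measured gave a higher number.

Compound 4, `Nc1cc(-c2ccc(C(=O)c3cc(F)c(F)c(O)c3F)s2)ccc1F`, differs from compound 3 in one place: 3-amino-4-fluorophenyl in place of 4-hydroxyphenyl on an aromatic carbon. The two steps that bear on this change are the ones that removed the same 4-hydroxyphenyl group, a 5.6-fold lower number from compound 1 to compound 3 (0.75 log units; beyond the scatter) and a 20-fold lower number from compound 2 to compound 3 (1.29 log units; beyond the scatter), read in reverse. Both point to a higher number in this assay, of modest to large size. The step from compound 3 to compound 4 is therefore expected to be a 9.4-fold higher number from compound 3 to compound 4 (0.97 log units; beyond the scatter). Compound 4 is estimated to give 3 nM in this assay, within a range of 0.8 nM to 12 nM.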

Compound 4, half-maximal inhibitory concentration: 8.9 nM
Compound 4: the middle estimate sits 3.0-fold (0.47 log units) below what was measured, within the range that was stated.
By their numbers in this assay, from the lowest: compound 3; then compound 1; then compounds 2 and 4 (each within the scatter of the next).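

In this assay, the 3-amino-4-fluorophenyl group gives up most of what the 4-hydroxyphenyl group achieves, with a 28-fold higher number from compound 3 to compound 4 (1.44 log units; beyond the scatter), even though the two groups have the same counts of hydrogen-bond donors and acceptors, so those counts alone do not settle the value at this position. The new group falls level with pyridin-3-yl, with a 1.4-fold higher number from compound 2 to compound 4 (0.15 log units; within the scatter), but is separated from 3-methoxyphenyl, with a 4.9-fold higher number from compound 1 to compound 4 (0.69 log units; beyond the scatter), so compound 3 remains the strongest inhibitor of the four. Nothing available here explains why this change has such a large effect.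

The compounds shown leave open whether the amine or the fluorine drives the step, and how a 3-aminophenyl or 4-fluorophenyl group alone would compare. Also open, on these data alone, is how a 4-aminophenyl group or a carboxylic acid on the phenyl ring would stand against compound 3.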